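This account rests on a few compounds, and the source may have more. Where it says the series, first, only, none or still open, it means among the compounds named here.

In a functional assay on HT-29 cells (Homo sapiens) for inhibition, read by sulforhodamine B assay, with a stated time of 48 h (a higher number here means a weaker inhibitor of growth, a lower number a stronger inhibitor of growth), compound 2 (`CC(C)(C)NCc1c(C(=O)O)nn(-c2ccccc2)c1-c1ccccc1`) reaches only a limit, > 716000 nM with no actual number. Compound 1 (`CC(C)(C)NCc1c(C(=O)O)nn(-c2ccccc2)c1-c1ccc(Br)cc1`) also reaches only a limit, > 585000 nM again without a number. Compound 3 (`Cc1ccc(-c2c(CNC(C)(C)C)c(C(=O)O)nn2-c2ccccc2)cc1`) likewise gives a limit, > 688000 nM and nothing firmer. Compound 4 (`CC(C)(C)NCc1c(C(=O)O)nn(-c2ccc(Cl)cc2)c1-c1ccccc1`) differs from compound 2 by chloro in place of hydrogen on an aromatic carbon, turning phenyl to 4-chlorophenyl (chloro in place of hydrogen on an aromatic carbon). The closest measured changes are a step that the two limits leave unreadable from compound 1 to compound 2 and a step that the two limits leave unreadable from compound 2 to compound 3 and neither offers a size to carry over. Both also fall on a different aromatic ring. The expected change is an at least 1.1-fold lower number from compound 2 to compound 4 (0.04 log units; that floor lies within the scatter) with no shift in either direction beyond the scatter. The estimate for compound 4 is 650000 nM with an expected range from 350000 nM to 900000 nM and probably only a limit again.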

Compound 4, concentration for 50% growth inhibition: > 652000 nM
Compound 4 ended at the assay's limit (the forecaster's own chance of this, stated with the estimate: 85%); middle value at least 1.0-fold (0.00 log units) away from the limit.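

Among the compounds shown here, compound 2 and compound 4 each give only a limit, not a number, so no step between them can be read. The compounds shown leave open whether chloro in place of hydrogen changes growth inhibition at all.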